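Swapping a halogen for ethoxy on the shared core

A few compounds are considered here, and "the series" means these few. Any claim that something is new, unique, unknown or untested is made for them only; others in the source may bear on it.

Compound 1, `COc1ccccc1Sc1c[nH]c2ccc(Cl)cc12`: 17500 nM
Compound 2, `COc1ccccc1Sc1c[nH]c2ccc(Br)cc12`: 24000 nM
Compound 3, `COc1ccccc1Sc1c[nH]c2ccc(I)cc12`: 45000 nM

In an assay on isolated protein for inhibition of Indoleamine 2,3-dioxygenase 1 (Homo sapiens), read by HPLC, with a stated time of 60 min, in the presence of a further agent that is not named here (a higher number here means a weaker inhibitor, a lower number a stronger inhibitor), compound 3 gives the highest of the three numbers. The closest measured number is reached by a 1.9-fold higher number from compound 2 to compound 3 (0.27 log units; within the scatter); the widest gap is a 2.6-fold higher number from compound 1 to compound 3 (0.41 log units; beyond the scatter).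

Compound 4, `CCOc1ccc2[nH]cc(Sc3ccccc3OC)c2c1`, differs from compound 3 in one place: ethoxy in place of iodo on an aromatic carbon. The measured steps all exchange one halogen for another: a 1.4-fold higher number from compound 1 to compound 2 (0.14 log units; within the scatter), a 1.9-fold higher number from compound 2 to compound 3 (0.27 log units; within the scatter) and a 2.6-fold higher number from compound 1 to compound 3 (0.41 log units; beyond the scatter). None of them replaces a halogen with ethoxy, so they bear on this change only loosely, showing that the three numbers stay in a narrow band. The step is expected to be modest in either direction, a 1.8-fold lower number from compound 3 to compound 4 (0.26 log units; within the scatter). Compound 4 is therefore estimated at 25000 nM, in a range from 8000 nM to 80000 nM.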

Compound 4, half-maximal inhibitory concentration: > 200000 nM
Compound 4 gave a limit, no number (the forecaster's own chance of this, stated with the estimate: 10%); middle value at least 8.0-fold (0.90 log units) from the limit.
By their numbers in this assay, from the lowest: compounds 1, 2 and 3 (each within the scatter of the next, the first and the last beyond it). At a limit, above all of these: compound 4.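

In this assay, compound 4 reads only as a limit of the assay, not a number: the limit of > 200000 nM in this assay, at which 1 of the 4 values shown sits. Ethoxy in place of halogen on this aromatic carbon therefore gives an at least 4.4-fold higher number from compound 3 to compound 4 (0.64 log units; beyond the scatter), an at least 8.3-fold higher number from compound 2 to compound 4 (0.92 log units; beyond the scatter) and an at least 11-fold higher number from compound 1 to compound 4 (1.05 log units; beyond the scatter), all beyond the scatter. So this position is not indifferent to its group, as the halogen exchanges alone might have suggested.

The compounds shown leave open whether the oxygen or the length of the ethoxy group matters more. A plain ethyl chain or an amine at this position would help separate those possibilities.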